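The compounds below may be only part of what the source reports. "The series", "measured", "known", "first", "only" and "open" are said of these compounds alone.

Measured compounds:
compound 1 `Cc1ccc(-c2cc(Cl)cc(Nc3cc(C)nc(N)n3)c2)cc1` — > 63000 nM
compound 2 `CC(=O)c1ccc(-c2cc(Cl)cc(Nc3cc(C)nc(N)n3)c2)cc1` — > 21000 nM

In an assay on cells for inhibition of S-adenosylmethionine decarboxylase proenzyme (Homo sapiens), read by mass spectrometry, at pH 7.2 (a higher number here means a weaker inhibitor, a lower number a stronger inhibitor), compound 1 gives > 63000 nM, which is a limit of the assay and not a number. Compound 2 gives > 21000 nM in this assay, again a limit rather than a number. For the measured compounds named here, the one step between measured compounds, a step that the two limits leave unreadable from compound 1 to compound 2, is acetyl in place of methyl on an aromatic carbon; with both ends at limits (the limit of > 21000 nM in this assay, at which 1 of the 2 values shown sits, and (the limit of > 63000 nM in this assay, at which 1 of the 2 values shown sits)) its size cannot be read.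

Compound 3 `Cc1cc(Nc2cc(Cl)cc(-c3cncnc3)c2)nc(N)n1` differs from compound 1 by pyrimidin-5-yl in place of 4-methylphenyl on an aromatic carbon. Going by the values given here, no measured step bears on this change, and the one step that exists is unreadable, so no direction beyond the scatter can be expected. Compound 3 is therefore estimated at 70000 nM in this assay, in a range from 10000 nM to 300000 nM. The expected step is a step that the limit leaves unreadable from compound 1 to compound 3.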

Compound 3, half-maximal inhibitory concentration: > 180000 nM
Compound 3: no number, only a limit; the forecaster's own chance of this, stated with the estimate: 80%; middle value at least 2.5-fold (0.41 log units) from the limit.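

Compound 3, like compound 1, gives a limit and not a number, so the size of the step between these two compounds cannot be read. The compounds shown leave open whether any group at this position gives a readable number in this assay.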